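This account rests on a few compounds, and the source may have more. Where it says the series, first, only, none or still open, it means among the compounds named here.

For the measured compounds named here, compound 1 `c1cc(-c2ccn[nH]2)c2c(c1)C(c1ncc[nH]1)CC2` is the one compound of this pair with a full number. Going by the values given here, in a functional assay on CHO cells for agonist activity at Alpha-1D adrenergic receptor (Homo sapiens), read by FLIPR and calcium flux (on this read-out lower numbers stand for an effect already at smaller amounts and higher numbers for an effect only at larger amounts of compound), compound 1 gives 336 nM, the only number among the values shown. Compound 2 `CS(=O)(=O)Nc1c(Cl)ccc2c1CCCC2c1ncc[nH]1` gives in this assay only a limit of the assay, > 10000 nM. Compound 1 thus stands alone against (the limit of > 10000 nM in this assay, at which 1 of the 2 values shown sits).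

Compound 3 `CNC(=O)c1cccc2c1CCC2c1ncc[nH]1` differs from compound 1 by methylcarbamoyl in place of 1H-pyrazol-5-yl on an aromatic carbon. No step between measured compounds is shown, so the expected size rests on the change itself, and a weakening step is expected, of the size a 4.5-fold higher number from compound 1 to compound 3 (0.65 log units; beyond the scatter). Compound 3 is accordingly estimated at 1500 nM, within a range from 300 nM to 10000 nM.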

Compound 3, half-maximal effective concentration: > 10000 nM
Compound 3 gave a limit, no number; the forecaster's own chance of this, stated with the estimate: 30%; at least 6.6-fold (0.82 log units) between middle value and limit.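

With methylcarbamoyl in place of 1H-pyrazol-5-yl on this aromatic carbon, this assay shows an at least 29-fold higher number from compound 1 to compound 3 (1.47 log units; beyond the scatter), a step that rests on a limit of the assay and not on a number. The change thus matters at this position, although both groups count the same hydrogen-bond donors and acceptors. Compound 1 remains the only compound with a full number: the limit of > 10000 nM in this assay, at which 2 of the 3 values shown sit.

On these data alone, whether a phenyl ring, an imidazole or a small amine on this carbon would give a measurable value stays open. So does the true size of the step.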